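The source may report more compounds than this note shows. Statements on the series, on what has been measured and on what is new or still open speak of the compounds shown alone.

Measured in a physicochemical assay for solubility, in phosphate buffer, measured as kinetic solubility, with a stated time of 24 h, at pH 7.4; a lower number here means a less soluble compound, a higher number a more soluble compound:
- Compound 1 `CC(C)CN(Cc1ccc(N2CCN(NS(C)(=O)=O)CC2)cc1)S(=O)(=O)Cc1ccccc1`: <= 1000 nM, a limit
- Compound 2 `CC(C)CN(Cc1ccc(N2CCN(C)CC2)cc1)S(=O)(=O)Cc1ccccc1`: 60000 nM
- Compound 3 `CC(=O)N1CCN(c2ccc(CN(C(C)(C)C)S(=O)(=O)Cc3ccccc3)cc2)CC1`: <= 1000 nM, a limit

Compound 3 has no exact number in this assay. Its reading of <= 1000 nM is a limit of the assay. Compound 3 sits at the limit of <= 1000 nM in this assay, at which 2 of the 3 values shown sit.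

Compound 4 `CC(=O)N1CCN(c2ccc(CN(CCN(C)C)S(=O)(=O)Cc3ccccc3)cc2)CC1` differs from compound 3 by 2-(dimethylamino)ethyl in place of tert-butyl on a sulfonamide nitrogen. Going by the values given here, no measured step makes this same exchange. Among the compounds with values here, the only measured step, an at least 60-fold higher number from compound 1 to compound 2 (1.77 log units; beyond the scatter), is large, but it is a different change: methyl in place of methanesulfonamido on an amine nitrogen in a ring. With that change, compound 2 reads 60000 nM. This step bears on compound 4 only indirectly, by showing that one structural change among these compounds can move the read-out far.

Resting on an at least 60-fold higher number from compound 1 to compound 2 (1.77 log units; beyond the scatter), a large rise in this assay is expected, with its size uncertain. The expected change is an at least 15-fold higher number from compound 3 to compound 4 (1.17 log units; beyond the scatter). For compound 4 the estimated value is 15000 nM, with an expected range from 1500 nM to 80000 nM.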

Compound 4, solubility: 221000 nM
The estimate for compound 4 lay 15-fold (1.17 log units) below the measured number, outside the stated range (above it).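

In this assay, 2-(dimethylamino)ethyl in place of tert-butyl on a sulfonamide nitrogen gives an at least 220-fold higher number from compound 3 to compound 4 (2.34 log units; beyond the scatter), a large step. Going by these compounds alone, the earlier compounds showed a large step only for an exchange on an amine nitrogen in a ring, so this is the first sign that the sulfonamide nitrogen is also a place where a single exchange can move the read-out far in this assay. The reading for compound 3 is a limit, so the step gives only a lower bound on the size of the change: the limit of <= 1000 nM in this assay, at which 2 of the 4 values shown sit.

With a single pair at this position, the compounds shown leave open whether the step follows from the nitrogen of the entering group or from the chain that carries it, and a pentyl chain of carbon alone or a carboxylic acid on the same sulfonamide nitrogen would help to separate the two. They also leave open whether the same exchange gives a step of similar size when the amine nitrogen in the ring carries a methyl or a methanesulfonamido group instead.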